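The source may report more compounds than this note shows. Statements on the series, on what has been measured and on what is new or still open speak of the compounds shown alone.

Going by the values given here, in a functional assay (aorta) with Oryctolagus cuniculus as the target (on this read-out lower numbers stand for tighter binding and higher numbers for weaker binding), compound 1 (`COc1cc(C(C)=O)ccc1OCCCN1CCC(C(c2ccc(F)cc2)c2ccc(F)cc2)CC1`) gives 1.59 nM, the lowest of the three numbers measured so far. Compound 2 (`COc1cc(C(C)=O)ccc1OCCCN1CCC(C(c2ccc(F)cc2)c2ccccn2)CC1`) gives 158 nM, and compound 3 (`COc1cc(C(C)=O)ccc1OCCCN1CCC(C(NC(C)=O)(c2ccc(F)cc2)c2ccc(F)cc2)CC1`) gives 63.1 nM. The two measured steps are a 99-fold higher number from compound 1 to compound 2 (2.00 log units; beyond the scatter) and a 40-fold higher number from compound 1 to compound 3 (1.60 log units; beyond the scatter). Both are large, but both were made on the saturated chain carbon and not on the carbonyl carbon.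

Compound 4 (`COC(=O)c1ccc(OCCCN2CCC(C(c3ccc(F)cc3)c3ccc(F)cc3)CC2)c(OC)c1`) differs from compound 1 in one place: methoxy in place of methyl on a carbonyl carbon. This is methoxy in place of methyl on a carbonyl carbon. Among the compounds with values here, no measured step touches that carbon, so the two large steps bear on it only indirectly and give no direct measure of its size. Starting from compound 1 at 1.59 nM, a modest move toward a higher number is expected in this assay, far smaller than either measured step. The estimated change is a 2.5-fold higher number from compound 1 to compound 4 (0.40 log units; beyond the scatter). Compound 4 is expected to read about 4 nM, with an estimated range of 1 nM to 16 nM.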

Compound 4, dissociation constant: 1.26 nM
Compound 4: the middle estimate sits 3.2-fold (0.50 log units) above what was measured; measured number inside the range.
By their numbers in this assay, from the lowest: compounds 4 and 1 (each within the scatter of the next); then compound 3; then compound 2.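

In this assay, methoxy in place of methyl on a carbonyl carbon gives a 1.3-fold lower number from compound 1 to compound 4 (0.10 log units; within the scatter), so the acetyl to methoxycarbonyl exchange does not separate the two compounds. The earlier steps shown here, both on the saturated chain carbon, could not show this: the carbonyl carbon accepts the extra heavy atom and hydrogen-bond acceptor counted for methoxy, at least in this one pair, whereas both chain-carbon changes gave large steps. No measured evidence bears on this result.

From the compounds shown here alone, how far this carbonyl carbon goes on accepting change stays open; a carboxylic acid, a primary amide or an ethoxy group in place of the methyl would extend the comparison. Also open, going by these compounds, is whether the same exchange reads alike on the cores of compound 2 and compound 3.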